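A few compounds are considered here, and "the series" means these few. Any claim that something is new, unique, unknown or untested is made for them only; others in the source may bear on it.

Compound 1 `N#Cc1ccc(NC(=O)c2ccc(Cl)cc2O)cc1`: 1920 nM
Compound 2 `O=C(Nc1ccc(C(F)(F)F)cc1)c1ccc(Cl)cc1O`: 580 nM

Among the compounds with values here, in a functional assay on KG-1 cells (Homo sapiens) for cytotoxicity, read by luminescence and CellTiter-Glo, with a stated time of 3 days (a higher number here means a weaker inhibitor, a lower number a stronger inhibitor), compound 2 gives 580 nM as the lower of the two numbers so far, so it stands ahead of compound 1 on this measure. Compound 3 `O=C(Nc1ccc(C(F)(F)F)cc1)c1ccc(Br)cc1O` is still unmeasured and differs from compound 2 by one swap: bromo in place of chloro on an aromatic carbon. It is bromo in place of chloro on an aromatic carbon, meta to a hydroxy group. Within the data shown here, the only measured step is a 3.3-fold lower number from compound 1 to compound 2 (0.52 log units; beyond the scatter) and it was modest, but it put trifluoromethyl in place of cyano at a different place, so it gives no direct size for this swap. No halogen swap has been measured yet, so a small change or none beyond the scatter is expected in this assay, with no firm direction. The expected step is a 1.2-fold lower number from compound 2 to compound 3 (0.06 log units; within the scatter) in this estimate. For compound 3 the estimated value is 500 nM, within an expected range of 220 nM to 1200 nM here.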

Compound 3, half-maximal inhibitory concentration: 340 nM
Compound 3: middle estimate off by 1.5-fold (0.17 log units), on the high side; the measured number falls inside the stated range.
By their numbers in this assay, from the lowest: compounds 3 and 2 (each within the scatter of the next); then compound 1.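

Within the data shown here, this is the first halogen swap, and in this assay putting bromo in place of chloro, on the aromatic carbon meta to a hydroxy group, gives a 1.7-fold lower number from compound 2 to compound 3 (0.23 log units; within the scatter). On this measure, compound 2 and compound 3 therefore cannot be told apart, so at this position bromo serves as well as chloro, while the earlier trifluoromethyl-for-cyano step at a different place went beyond the scatter. Nothing available explains why the two halogens read alike.

The compounds shown leave open whether a group other than a halogen, such as a methoxy group, an amine or a carboxylic acid, would read the same at this position. They also leave open how much the hydroxy group contributes, and whether bromo would behave the same way in the core of compound 1.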